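The source may hold more compounds than are shown below. What is called first, only, known or untested is meant among the compounds shown, and "the series" means these compounds.

Measured in a functional assay on K562 cells (Homo sapiens) for inhibition, read by sulforhodamine B assay, with a stated time of 48 h; a lower number here means a stronger inhibitor of growth, a higher number a weaker inhibitor of growth:
Compound 1 `CC1(/C=C/c2ccccc2)C=CC(=O)O1`: > 1000000 nM (a limit)
Compound 2 `CC1(/C=C/c2ccccc2C(F)(F)F)C=CC(=O)O1`: 573000 nM
Compound 3 `COc1ccc(/C=C/C2(C)C=CC(=O)O2)c(OC)c1`: > 1000000 nM (a limit)

Compound 3 gives > 1000000 nM, which is a limit of the assay and not a number. Compound 4 `COc1ccccc1/C=C/C1(C)C=CC(=O)O1` differs from it by hydrogen in place of methoxy on an aromatic carbon. Among the compounds with values here, no measured step removes a methoxy group. The closest evidence is an at least 1.7-fold lower number from compound 1 to compound 2 (0.24 log units; that floor lies within the scatter), which concerns a different group. Compound 1, which carries no methoxy group, also gives a limit, > 1000000 nM. With compound 3 and compound 1 both reported only as limits, no step beyond the scatter is expected, and compound 4 may well reach the same limit in this assay. The expected change is an at least 1.1-fold lower number from compound 3 to compound 4 (0.04 log units; that floor lies within the scatter). For compound 4 the estimated value is 900000 nM, with an expected range from 400000 nM to 1500000 nM.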

Compound 4, concentration for total growth inhibition: 860000 nM
Beside the measured number, compound 4's estimate is 1.0-fold (0.02 log units) above it; the range from low to high includes it.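

Compound 4 puts a number on a shared core that carries a single methoxy group on the aromatic ring, yet taking away the second methoxy group gives only an at least 1.1-fold lower number from compound 3 to compound 4 (0.06 log units; that floor lies within the scatter) in this assay, so this change is bounded on one side and shows nothing beyond the scatter. Adding the single methoxy group to the unsubstituted ring gives an at least 1.1-fold lower number from compound 1 to compound 4 (0.06 log units; that floor lies within the scatter), while methoxy in place of trifluoromethyl gives a 1.5-fold higher number from compound 2 to compound 4 (0.18 log units; within the scatter), so these two groups cannot be told apart at this aromatic carbon. Two of the three new steps are therefore only floors, set by a shared ceiling: the limit of > 1000000 nM in this assay, at which 2 of the 4 values shown sit.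

Going by these compounds, whether any group on this ring can move the number beyond the scatter remains open. An amine or a carboxylic acid on the same aromatic carbon would be a direct test of that question.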